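Alanine side-chain extension in the purine glycinamide series

The compounds below may be only part of what the source reports. "The series", "measured", "known", "first", "only" and "open" are said of these compounds alone.

Measured so far:
compound 1 `C[C@H](NC(=O)CN(c1nc(Cl)nc2[nH]cnc12)C1CC1)C(=O)O` — 48.1%
compound 2 `C[C@H](NC(=O)CN(c1nc(Cl)nc2[nH]cnc12)C1CC1)C(=O)OCc1ccccc1` — 41.2%

In a functional assay on the whole organism (Tail, strain ICR) with Mus musculus as the target, in the tail flick test, with a stated time of 30 min, at a dose of 25 umol/kg by the oral route (on this read-out lower numbers stand for a weaker effect and higher numbers for a stronger effect at the one dose given), compound 1 gives 48.1%, the higher of the two numbers, though only by a number 6.9 percentage points lower from compound 1 to compound 2 (within the scatter), a step made by placing benzyl in place of hydrogen on an oxygen beside the carbonyl group. Compound 3 `NCCCC[C@H](NC(=O)CN(c1nc(Cl)nc2[nH]cnc12)C1CC1)C(=O)O` differs from compound 1 by 3-aminopropyl in place of hydrogen on a saturated chain carbon, two bonds along the chain from an amide-type nitrogen and a carbonyl carbon. For the measured compounds named here, no measured step touches this chain carbon, so the single step on record does not bear on it directly; it only shows that one peripheral change left the read-out inside the scatter. The step to compound 3 is therefore estimated as a number 3.1 percentage points lower from compound 1 to compound 3 (within the scatter), none beyond the scatter. Compound 3 is expected to give 45%, within 25% to 65%.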

Compound 3, a percentage reported as activity, at one dose (the size of the read-out at that dose, not a potency): 31.2%
Beside the measured number, compound 3's estimate is 13.8 percentage points above it; the range from low to high includes it.
By their numbers in this assay, from the lowest: compounds 3, 2 and 1 (each within the scatter of the next, the first and the last beyond it).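

In this assay, for the compounds shown here, the saturated chain carbon tolerates less change than the earlier compounds could show: 3-aminopropyl in place of hydrogen gives a number 16.9 percentage points lower from compound 1 to compound 3 (beyond the scatter), the only step beyond the scatter. By contrast, benzyl in place of hydrogen on the oxygen gives a number 6.9 percentage points lower from compound 1 to compound 2 (within the scatter). No available evidence accounts for the weaker effect of compound 3. Open, as far as these compounds go, is whether the drop follows the terminal amine or the chain itself; a plain propyl group at this carbon would separate the two.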